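Hydroxamic acid series: swapping fluoro for tert-butyl on benzyl ring

The source may report more compounds than this note shows. Statements on the series, on what has been measured and on what is new or still open speak of the compounds shown alone.

Of the compounds shown here, three sharing one core have been measured in a functional assay on ACHN cells (Homo sapiens) for inhibition, read by sulforhodamine B assay; on this read-out higher numbers stand for weaker inhibition of growth and lower numbers for stronger inhibition of growth. Compound 1 `Cc1ccccc1CN1CC=C(CCC(=O)NO)C1=O` gives 3330 nM in this assay. Compound 2 `O=C(CCC1=CCN(Cc2ccc(F)cc2)C1=O)NO` gives 5990 nM in this assay, and compound 3 `O=C(CCC1=CCN(Cc2cccc(Br)c2)C1=O)NO` gives 3330 nM in this assay. Among these three numbers, compound 2 carries the highest, but its nearest neighbour is compound 1 at a gap stated to lie within the scatter, and the gap to compound 3 is likewise within the scatter; the three values therefore cannot be told apart.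

Compound 4 `CC(C)(C)c1ccc(CN2CC=C(CCC(=O)NO)C2=O)cc1` has not yet been measured in this assay. It differs from compound 2 in one place: tert-butyl in place of fluoro on an aromatic carbon. The substituent sits on the same aromatic carbon, para to a large group, so the shared core and the hydroxamic acid chain are untouched.

For the measured compounds named here, no step between measured compounds is available, so the expectation rests on the spread of the three values alone. The shift from fluoro to tert-butyl, a change in aryl substituent like those separating compounds 1, 2 and 3, is expected to bring only a small step, a 1.7-fold lower number from compound 2 to compound 4 (0.23 log units; within the scatter), not clearly beyond the scatter. Compound 4 is thus estimated at 3500 nM in this assay, with a range from 1500 nM to 8000 nM.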

Compound 4, concentration for 50% growth inhibition: 860 nM
Estimate against measurement, compound 4: 4.1-fold (0.61 log units) above; the whole stated range lies above it.
By their numbers in this assay, from the lowest: compound 4; then compounds 1, 3 and 2 (each within the scatter of the next).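

In this assay, replacing fluoro with tert-butyl on the aromatic carbon para to a large group gives a 7.0-fold lower number from compound 2 to compound 4 (0.84 log units; beyond the scatter), the first step shown between compounds that differ in one place. For the compounds shown here, at this position, therefore, a substituent of 4 heavy atoms in place of 1 heavy atom does not cost growth inhibition in these cells, and the shift runs towards stronger inhibition, a change of a size that the earlier compounds, with no step between them, could not reveal. Nothing measured here accounts for the step.

The compounds shown do not tell whether the gain depends on tert-butyl itself or would also appear with an isopropyl, a trifluoromethyl or a methoxy group on the same carbon. They also leave open how an amine or a carboxylic acid at this position would read out, and whether tert-butyl would give a similar step on the other carbons of this ring.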